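Sulfonyl substituent: from isobutyl to 2-fluorophenyl

The source may hold more compounds than are shown below. What is called first, only, known or untested is meant among the compounds shown, and "the series" means these compounds.

Compound 2 `CC(C)CS(=O)(=O)N1C[C@@H]2[C@H](C1)[C@@]2(CNC(=O)c1ccc(Cl)cc1Cl)CC1CC1` gives 2900 nM in an assay on isolated protein for inhibition of sodium- and chloride-dependent glycine transporter 1 (Homo sapiens); a higher number here means a weaker inhibitor, a lower number a stronger inhibitor; compound 1 `CC(C)S(=O)(=O)N1C[C@@H]2[C@H](C1)[C@@]2(CNC(=O)c1ccc(Cl)cc1Cl)CC1CC1` gives 3400 nM in this assay, and the two stand within the scatter of each other, the step of a 1.2-fold lower number from compound 1 to compound 2 (0.07 log units; within the scatter) being the only measured one. Compound 3 `O=C(NC[C@]1(CC2CC2)[C@@H]2CN(S(=O)(=O)c3ccccc3F)C[C@@H]21)c1ccc(Cl)cc1Cl` differs from compound 2 by 2-fluorophenyl in place of isobutyl on a sulfonyl sulfur. Among the compounds with values here, the one step that bears on this place, from isopropyl to isobutyl on the sulfonyl sulfur, was within the scatter, so nothing measured here points in a direction. Compound 3 is therefore expected at 2000 nM (range 400 nM to 9000 nM), an expected step of a 1.5-fold lower number from compound 2 to compound 3 (0.16 log units; within the scatter) with wide uncertainty.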

Compound 3, half-maximal inhibitory concentration: > 10000 nM
Compound 3: a limit, no number; the forecaster's own chance of this, stated with the estimate: 5%; middle value at least 5.0-fold (0.69 log units) from the limit.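

In this assay the sulfonyl sulfur proves sensitive to its substituent, with an at least 3.4-fold higher number from compound 2 to compound 3 (0.53 log units; beyond the scatter) and an at least 2.9-fold higher number from compound 1 to compound 3 (0.46 log units; beyond the scatter) on moving to 2-fluorophenyl, whereas isopropyl and isobutyl stood within the scatter of each other. Compound 3 gives > 10000 nM as a limit of the assay, not a number. As far as these compounds go, the true size of both steps therefore remains unknown.

The compounds shown do not separate the effect of the aromatic ring from that of the fluorine. From the compounds shown here alone, whether phenyl without fluorine, benzyl or a longer alkyl chain such as n-butyl would be tolerated remains open.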